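The source may report more compounds than this note shows. Statements on the series, on what has been measured and on what is new or still open speak of the compounds shown alone.

In a functional assay on B16-F10 cells (Mus musculus) for antiproliferative activity, read by MTT assay, with a stated time of 48 h (on this read-out lower numbers stand for stronger inhibition and higher numbers for weaker inhibition), compound 1 `COc1ccc(/C=C/c2cc(OC)cc(OC)c2/C=C/C(=O)c2cccc(OC)c2)cc1` gives 4.3 ug/mL, compound 2 `CCCC(C)Oc1ccc(C(=O)/C=C/c2c(/C=C/c3ccc(OC)cc3)cc(OC)cc2OC)cc1` gives 6.7 ug/mL and compound 3 `CCCCOc1ccc(C(=O)/C=C/c2c(/C=C/c3ccc(OC)cc3)cc(OC)cc2OC)cc1` gives 5.3 ug/mL, which places compound 3 within the scatter of both others. Compound 4 `COc1ccc(/C=C/c2cc(OC)cc(OC)c2/C=C/C(=O)c2cccc(Br)c2)cc1` has 3-bromophenyl in place of the 4-butoxyphenyl of compound 3 on a carbonyl carbon (3-bromophenyl in place of 4-butoxyphenyl on a carbonyl carbon). Two measured steps changed the group at this same carbon, a 1.6-fold higher number from compound 1 to compound 2 (0.19 log units; within the scatter) and a 1.2-fold higher number from compound 1 to compound 3 (0.09 log units; within the scatter), and the chain change, a 1.3-fold lower number from compound 2 to compound 3 (0.10 log units; within the scatter), was just as modest. For the measured compounds named here, no measured compound carries bromine, so the evidence is indirect, and no step beyond the scatter is expected in this assay. The expected result is a 1.2-fold lower number from compound 3 to compound 4 (0.07 log units; within the scatter). For compound 4 the estimated value is 4.5 ug/mL, within an expected range of 2 ug/mL to 9.5 ug/mL.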

Compound 4, half-maximal inhibitory concentration: 5.1 ug/mL
Compound 4: middle estimate off by 1.1-fold (0.05 log units), on the low side, and the stated range covers the measured number.
By their numbers in this assay, from the lowest: compounds 1, 4, 3 and 2 (each within the scatter of the next).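

Bromine enters the series here, and in this assay the 3-bromophenyl on the carbonyl carbon gives a 1.0-fold lower number from compound 3 to compound 4 (0.02 log units; within the scatter) and a 1.3-fold lower number from compound 2 to compound 4 (0.12 log units; within the scatter), so replacing either alkoxy-bearing ring leaves the number within the scatter. With bromo in place of methoxy on an aromatic carbon there is a 1.2-fold higher number from compound 1 to compound 4 (0.07 log units; within the scatter), so this change at the same ring also leaves the read-out unmoved. Nothing available explains this flat response. Still open, from the compounds shown here alone, is whether an amine or a carboxylic acid on this phenyl ring would give a step beyond the scatter. Also open, going by these compounds, is how a fluoro or chloro group would compare with bromo here.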